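The source may report more compounds than this note shows. Statements on the series, on what has been measured and on what is new or still open speak of the compounds shown alone.

Measured compounds:
- compound 1 `O=C(Nc1cccc(F)c1)C(Cl)Cl` — "not determined" (no result reported)
- compound 2 `O=C(Nc1cccc(Cl)c1)C(Cl)Cl` — "not determined" (no result reported)
- compound 3 `O=C(Nc1cccc(Br)c1)C(Cl)Cl` — 95300 nM

The series shares one amide core carrying a dichloro-substituted acetyl group and differs only in the halogen on the aromatic ring. For the measured compounds named here, in a functional assay on BGC-823 cells (Homo sapiens) for antiproliferative activity, read by MTT assay, with a stated time of 72 h (a higher number here means a weaker inhibitor, a lower number a stronger inhibitor), compound 3 gives 95300 nM, and this is the only number in the set; in this assay compound 1 gives "not determined" (no result reported) and compound 2 gives "not determined" (no result reported), so no step between measured compounds can be stated, and nothing about a trend across the halogens is known from these data. Compound 3 therefore stands alone as the sole reference point, a weak inhibitor by its number.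

Compound 4 `O=C(Nc1cccc(I)c1)C(Cl)Cl` is the next member and is to be measured in this assay. It differs from compound 3 by iodo in place of bromo on an aromatic carbon. Going by the values given here, with no counted step in hand, the change is expected to be modest and of uncertain direction, most likely not beyond the scatter; the step from compound 3 to compound 4 is expected at a 1.4-fold lower number from compound 3 to compound 4 (0.13 log units; within the scatter). For compound 4 the estimated value is 70000 nM, within a range of 25000 nM to 200000 nM.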

Compound 4, half-maximal inhibitory concentration: 58800 nM
The estimate for compound 4 lay 1.2-fold (0.08 log units) above the measured number; low and high end bracket the measured number.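

In this assay, for the compounds shown here, iodo in place of bromo on an aromatic carbon, meta to a group of 6 heavy atoms, gives the first readable step, a 1.6-fold lower number from compound 3 to compound 4 (0.21 log units; within the scatter), so this exchange does not separate the two compounds. The low activity of compound 3 is therefore not a lone reading, since the iodo analogue compound 4 gives 58800 nM in the same assay. No measurement at hand bears on the cause of this result.

On these data alone, the steps to the fluoro and chloro compounds cannot be read, so any order across the four halogens stays open. Also open, as far as these compounds go, is whether an amine or a carboxylic acid at this ring position, or a longer chain in place of the dichloro-substituted acetyl group, would shift the number beyond the scatter.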